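The source may report more compounds than this note shows. Statements on the series, on what has been measured and on what is new or still open speak of the compounds shown alone.

Three compounds share one core and differ only in the aryl group on the amide nitrogen. Compound 1 `COc1ccc(C)cc1NC(=O)CSc1nnc(-c2ccoc2C)n1Cc1ccco1` carries a 2-methoxy-5-methylphenyl group and in a functional assay on CHO cells for antagonist activity at Orexin receptor type 2 (Homo sapiens), read by FLIPR and calcium flux (on this read-out higher numbers stand for weaker inhibition and lower numbers for stronger inhibition), compound 1 gives 15.9 nM. Compound 2 `Cc1occc1-c1nnc(SCC(=O)Nc2ccc(F)cc2)n1Cc1ccco1` carries a 4-fluorophenyl group, and in this assay compound 2 gives 158 nM. Compound 3 `Cc1occc1-c1nnc(SCC(=O)Nc2ccc(Cl)cc2)n1Cc1ccco1` carries a 4-chlorophenyl group, and in this assay compound 3 gives 100 nM; its number is the second highest of the three, with compound 2 nearest and compound 1 furthest.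

For the measured compounds named here, the steps so far: a 9.9-fold higher number from compound 1 to compound 2 (1.00 log units; beyond the scatter) and a 6.3-fold higher number from compound 1 to compound 3 (0.80 log units; beyond the scatter) mark the loss on leaving the 2-methoxy-5-methylphenyl group, while a 1.6-fold lower number from compound 2 to compound 3 (0.20 log units; within the scatter) shows that swapping the halogen hardly matters.

Compound 4 `Cc1occc1-c1nnc(SCC(=O)Nc2cccc(Cl)c2)n1Cc1ccco1` keeps the same atoms as compound 3 but joins them differently: 3-chlorophenyl in place of 4-chlorophenyl on an amide-type nitrogen. Going by the values given here, no measured step moves the chlorine around the ring, so the closest guidance is the small halogen swap, which stayed within the scatter. For compound 4 in this assay, a step of a 1.4-fold lower number from compound 3 to compound 4 (0.15 log units; within the scatter) is expected, that is, no change beyond the scatter. Compound 4 is therefore estimated at 70 nM, within a range from 25 nM to 200 nM.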

Compound 4, inhibition constant: 63.1 nM
For compound 4 the middle estimate is 1.1-fold (0.05 log units) above the measured one; the range from low to high includes it.
By their numbers in this assay, from the lowest: compound 1; then compounds 4, 3 and 2 (each within the scatter of the next, the first and the last beyond it).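

Moving the chlorine from 4-chlorophenyl to 3-chlorophenyl on the amide-type nitrogen gives a 1.6-fold lower number from compound 3 to compound 4 (0.20 log units; within the scatter) in this assay, so this first look at where the chlorine sits shows no real change. Changing both the halogen and its place does separate two aryl groups, with a 2.5-fold lower number from compound 2 to compound 4 (0.40 log units; beyond the scatter), although compound 3 lies within the scatter of both compound 2 and compound 4, while a 4.0-fold higher number from compound 1 to compound 4 (0.60 log units; beyond the scatter) shows that the 3-chlorophenyl group still falls short of the 2-methoxy-5-methylphenyl group. Nothing measured here explains these differences.

The compounds shown leave open whether the methoxy or the methyl of the 2-methoxy-5-methylphenyl group accounts for the lower number of compound 1. On these data alone, how a plain phenyl, or a phenyl bearing a nitrile or a carboxylic acid, would read also remains open.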